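Working notes on the step from compound 3 to compound 4

The source may report more compounds than this note shows. Statements on the series, on what has been measured and on what is new or still open speak of the compounds shown alone.

Of the compounds shown here, three have been measured in an assay on Sf9 cells for inhibition of protein deacetylase HDAC6 (Homo sapiens), read by fluorescence; a lower number here means a stronger inhibitor, a higher number a weaker inhibitor. Compound 1 `O=C(NO)c1ccc(Cn2nnc(-c3ccccn3)n2)cc1` gives 9 nM, compound 2 `Nc1ccc(-c2nnn(Cc3ccc(C(=O)NO)cc3)n2)cc1` gives 1 nM, and compound 3 `O=C(NO)c1ccc(Cn2nnc(-c3ncccn3)n2)cc1` gives 7 nM. Compound 3 stands second highest of the three numbers: its nearest neighbour is compound 1, with a 1.3-fold lower number from compound 1 to compound 3 (0.11 log units; within the scatter), a gap within the scatter; its furthest is compound 2, with a 7.0-fold higher number from compound 2 to compound 3 (0.85 log units; beyond the scatter).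

Compound 4 `O=C(NO)c1ccc(Cn2nnc(Cc3ccccn3)n2)cc1` differs from compound 3 in one place: (pyridin-2-yl)methyl in place of pyrimidin-2-yl on an aromatic carbon. Within the data shown here, the one measured step that swaps a six-membered heteroaryl ring for another at this position is a 1.3-fold lower number from compound 1 to compound 3 (0.11 log units; within the scatter), within the scatter. The steps of a 9.0-fold lower number from compound 1 to compound 2 (0.95 log units; beyond the scatter) and a 7.0-fold higher number from compound 2 to compound 3 (0.85 log units; beyond the scatter) concern the 4-aminophenyl group, which compound 4 does not carry, so they do not bear directly on it. Among the measured compounds shown here, no measured pair shows what the change from pyrimidin-2-yl to (pyridin-2-yl)methyl does, so the step of a 1.7-fold higher number from compound 3 to compound 4 (0.23 log units; within the scatter) is expected to stay within the scatter, with a wide band to cover the unknown. Compound 4 is therefore estimated at 12 nM, with a range from 4 nM to 40 nM.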

Compound 4, half-maximal inhibitory concentration: 25 nM
The estimate for compound 4 lay 2.1-fold (0.32 log units) below the measured number; the measured number falls inside the stated range.
By their numbers in this assay, from the lowest: compound 2; then compounds 3 and 1 (each within the scatter of the next); then compound 4.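

In this assay, among these compounds, the position had so far responded only to the 4-aminophenyl group, with the exchange of one directly attached heteroaryl ring for another staying within the scatter; (pyridin-2-yl)methyl now gives steps beyond the scatter against both such rings, a 3.6-fold higher number from compound 3 to compound 4 (0.55 log units; beyond the scatter) and a 2.8-fold higher number from compound 1 to compound 4 (0.44 log units; beyond the scatter). The step against the 4-aminophenyl group is the largest here, a 25-fold higher number from compound 2 to compound 4 (1.40 log units; beyond the scatter), and compound 4 carries the highest number of the four, with its steps to all three others beyond the scatter. Nothing available accounts for these shifts.

Still open, on these data alone, is whether a longer chain, such as 2-(pyridin-2-yl)ethyl, would raise the number further. Also open, as far as these compounds go, is whether a benzyl group or a 4-aminobenzyl group would follow the same trend as (pyridin-2-yl)methyl.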